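The source may report more compounds than this note shows. Statements on the series, on what has been measured and on what is new or still open speak of the compounds shown alone.

Values in an ADME assay on HEK-293T cells (Homo sapiens) for inhibition, read by CCK-8 assay, with a stated time of 48 h, tested at 20 uM; a higher number here means more inhibition of growth at the concentration tested, a lower number less inhibition of growth

compound 1 `N#C/C(=C\c1ccccc1OS(=O)(=O)c1ccc([N+](=O)[O-])cc1)C(=O)Nc1nnc(Cc2cccc3ccccc23)s1` at 25%
compound 2 `N#C/C(=C\c1ccccc1OS(=O)(=O)c1ccc([N+](=O)[O-])cc1)C(=O)Nc1nnc(Cc2ccc(F)cc2)s1` at 8%
compound 3 `Cc1ccc(Cc2nnc(NC(=O)/C(C#N)=C/c3ccccc3OS(=O)(=O)c3ccc(C)cc3)s2)cc1` at 22%

Compound 3 gives 22% within the scatter of compound 1 and beyond the scatter above compound 2. All three numbers are low for a single tested concentration.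

Compound 4 `Cc1ccc(Cc2nnc(NC(=O)/C(C#N)=C/c3ccccc3OS(=O)(=O)c3ccc([N+](=O)[O-])cc3)s2)cc1` differs from compound 3 by a single change nitro in place of methyl on an aromatic carbon that turns (4-methylphenyl)sulfonyl into (4-nitrophenyl)sulfonyl. Among the measured compounds shown here, no measured step makes this change. For the measured compounds named here, the only measured step, a number 17 percentage points lower from compound 1 to compound 2 (beyond the scatter) (4-fluorophenyl in place of naphthalen-1-yl), is modest and lies at another place in the molecule, so it bears on the question only indirectly.

More useful is that compound 1 and compound 2 already carry (4-nitrophenyl)sulfonyl. With that group present, compound 1 at 25% stays within the scatter of compound 3, while compound 2 at 8% falls beyond it. Two compounds are a thin basis, so the range stays wide.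

The expected move in this assay is a number 4 percentage points lower from compound 3 to compound 4 (within the scatter) and so stays inside the scatter, slightly downward. Compound 4 is estimated at 18% within an expected range of 6% to 32% for this read-out.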

Compound 4, percent growth inhibition at one concentration: 9%
For compound 4 the middle estimate is 9 percentage points above the measured one, and the stated range covers the measured number.
By their numbers in this assay, from the lowest: compounds 2 and 4 (each within the scatter of the next); then compounds 3 and 1 (each within the scatter of the next).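

In this assay the sulfonyl-bound ring now has its first direct comparison: a number 13 percentage points lower from compound 3 to compound 4 (beyond the scatter) for nitro in place of methyl, with 4-methylphenyl held at the other end of the core. With (4-nitrophenyl)sulfonyl held, the other end can also be read against compound 4: a number 1 percentage points higher from compound 2 to compound 4 (within the scatter) for methyl in place of fluoro and a number 16 percentage points lower from compound 1 to compound 4 (beyond the scatter) for 4-methylphenyl in place of naphthalen-1-yl, so nitro does not fix a low number on its own, as compound 1 stands apart from the other two nitro compounds. The data offer no measurement that accounts for either the step at this position or the higher number of compound 1.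

As far as these compounds go, it remains open whether the step from methyl to nitro has the same size with naphthalen-1-yl or 4-fluorophenyl at the other end of the core, as it rests on a single pair here. Also open, from the compounds shown here alone, is how an amine or a carboxylic acid on this ring, in place of nitro or methyl, would read in this assay.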